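A few compounds are considered here, and "the series" means these few. Any claim that something is new, unique, unknown or untested is made for them only; others in the source may bear on it.

Compounds measured so far:
- compound 1, `COc1cc(Oc2cccc(Nc3ccccc3)c2)cc(OC)c1CNCCNC(C)=O`: 3960 nM
- compound 2, `COc1cc(Oc2cccc(Nc3ccccc3)c2)cc(OC)c1CNC(C)C`: a limit, > 20000 nM
- compound 3, `COc1ccc(CCCNCc2c(OC)cc(Oc3cccc(Nc4ccccc4)c3)cc2OC)cc1`: 3320 nM

In a functional assay on HT-29 cells (Homo sapiens) for inhibition, read by MTT assay, with a stated time of 72 h (on this read-out higher numbers stand for weaker inhibition and lower numbers for stronger inhibition), compound 1 gives 3960 nM. Among the two numbers, compound 1 stands highest, and compound 3 sits nearest at a 1.2-fold lower number from compound 1 to compound 3 (0.08 log units; within the scatter), so the two cannot be told apart. Compound 2 reports only a limit, > 20000 nM, so its value is not a number; that limit is the limit of > 20000 nM in this assay, at which 1 of the 3 values shown sits.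

Compound 4, `COc1cc(Oc2cccc(Nc3ccccc3)c2)cc(OC)c1CN[C@H](C)c1ccccc1`, has not yet been measured. It differs from compound 1 by 1-phenylethyl in place of 2-acetamidoethyl on an amine nitrogen.

Going by the values given here, two measured steps bear on this. Replacing the same 2-acetamidoethyl with isopropyl gave an at least 5.0-fold higher number from compound 1 to compound 2 (0.70 log units; beyond the scatter), a loss of inhibition. Going from isopropyl to 3-(4-methoxyphenyl)propyl, a group carrying an aromatic ring, gave an at least 6.0-fold lower number from compound 2 to compound 3 (0.77 log units; beyond the scatter), recovering it. The 1-phenylethyl entering in compound 4 carries an aromatic ring, which speaks for keeping inhibition near compound 1, yet the acetamido hydrogen-bond donor and acceptor are lost. A modest weakening is therefore expected, a 1.8-fold higher number from compound 1 to compound 4 (0.25 log units; within the scatter). Compound 4 is expected to give 7000 nM, between 2500 nM and 20000 nM.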

Compound 4, half-maximal inhibitory concentration: 5120 nM
Beside the measured number, compound 4's estimate is 1.4-fold (0.14 log units) above it; the range from low to high includes it.
By their numbers in this assay, from the lowest: compounds 3, 1 and 4 (each within the scatter of the next). At a limit, above all of these: compound 2.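

In this assay, putting 1-phenylethyl on the amine nitrogen in place of 2-acetamidoethyl gives a 1.3-fold higher number from compound 1 to compound 4 (0.11 log units; within the scatter), so a group with no hydrogen-bond donor or acceptor can stand in for the acetamido-bearing chain at this position. Two quite different groups carrying an aromatic ring also cannot be told apart here, as 1-phenylethyl in place of 3-(4-methoxyphenyl)propyl gives a 1.5-fold higher number from compound 3 to compound 4 (0.19 log units; within the scatter), while 1-phenylethyl in place of isopropyl gives an at least 3.9-fold lower number from compound 2 to compound 4 (0.59 log units; beyond the scatter). That last step has only a minimum size, since compound 2 is reported as a limit and not a number: the limit of > 20000 nM in this assay, at which 1 of the 4 values shown sits.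

The compounds shown leave open whether the mirror-image form of 1-phenylethyl would behave the same way, since only one defined stereocentre appears. From the compounds shown here alone, it is also open whether a plain benzyl group or a chain ending in a carboxylic acid would match compound 4 or fall away like compound 2.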